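The source may report more compounds than this note shows. Statements on the series, on what has been measured and on what is new or still open speak of the compounds shown alone.

Compound 1 `Cn1c(-c2ccc(NC(=O)CSc3nc4ccccc4o3)cc2)nc(-c2ccccc2)c1-c1ccccc1` gives 18.7% in a functional assay on MCF7 cells (Homo sapiens) for cytotoxicity, read by MTT assay, with a stated time of 24 h, tested at 0.64 ug/mL; a higher number here means a stronger effect of the compound at the concentration tested, a lower number a weaker effect.
Compound 2 `Cc1ccc2oc(SCC(=O)Nc3ccc(-c4nc(-c5ccccc5)c(-c5ccccc5)n4C)cc3)nc2c1` gives 1.1% in this assay.
Compound 3 `Cn1c(-c2ccc(NC(=O)CSC3=NCCS3)cc2)nc(-c2ccccc2)c1-c1ccccc1` gives 10.3% in this assay.

Compound 3 stands second highest of the three numbers. Its nearest neighbour is compound 1, with a number 8.4 percentage points lower from compound 1 to compound 3 (within the scatter), and its furthest is compound 2, with a number 9.2 percentage points higher from compound 2 to compound 3 (within the scatter); both gaps lie within the scatter. Going by the values given here, the one step beyond the scatter is a number 17.6 percentage points lower from compound 1 to compound 2 (beyond the scatter).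

Compound 4 `CCN1CCN(CC(=O)Nc2ccc(-c3nc(-c4ccccc4)c(-c4ccccc4)n3C)cc2)CC1` differs from compound 3 in one place: a group of 8 heavy atoms (6 carbon, 2 nitrogen; one six-membered non-aromatic ring with 2 hetero atoms) in place of a group of 6 heavy atoms (3 carbon, 1 nitrogen, 2 sulfur; one five-membered non-aromatic ring with 2 hetero atoms), on a saturated chain carbon bound to a carbonyl carbon. Among the compounds with values here, the steps that bear on it, from compound 1 to compound 3 and from compound 2 to compound 3, each swapped the group on the sulfur and stayed within the scatter. Within the data shown here, no measured step replaces the sulfur-linked ring itself with a nitrogen-linked ring on the chain carbon, so the direction is open. The step expected is a number 0.3 percentage points lower from compound 3 to compound 4 (within the scatter), not beyond the scatter. Compound 4 is therefore expected to give 10% in this assay, within a range from 1% to 25%.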

Compound 4, a percentage reported as activity, at one concentration (the size of the read-out at that concentration, not a potency): 4.7%
For compound 4 the middle estimate is 5.3 percentage points above the measured one, and the stated range covers the measured number.
By their numbers in this assay, from the lowest: compounds 2, 4, 3 and 1 (each within the scatter of the next, the first and the last beyond it).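

On the saturated chain carbon bound to a carbonyl carbon, 4-ethylpiperazin-1-yl is the first group shown that is joined through nitrogen rather than sulfur, and in this assay the swap stays within the scatter against two of the sulfur-linked groups: a number 5.6 percentage points lower from compound 3 to compound 4 (within the scatter) and a number 3.6 percentage points higher from compound 2 to compound 4 (within the scatter). Only against (1,3-benzoxazol-2-yl)sulfanyl does the swap go beyond the scatter, with a number 14 percentage points lower from compound 1 to compound 4 (beyond the scatter), so compound 1 now stands apart from both compound 2 and compound 4. Nothing available explains why this group gives such a reading.

The compounds shown leave open how a morpholine ring, or a piperazine carrying benzyl in place of ethyl, would read on the same chain carbon. They also leave open whether a simple dimethylamino group would fall in the same range as 4-ethylpiperazin-1-yl.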